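The source may hold more compounds than are shown below. What is called first, only, known or untested is meant among the compounds shown, and "the series" means these compounds.

Measured compounds:

Compound 1, `CCCCCCCO/N=C/c1cc(OC)c2c(c1OC)C(=O)C=CC2=O`: 0.213 ug/mL in a functional assay on L1210 cells (Mus musculus) for antiproliferative activity; a lower number here means that less compound is needed, a higher number that more compound is needed for the effect
Compound 2, `CCCCCC/C(=N\OCCCCC)c1cc(OC)c2c(c1OC)C(=O)C=CC2=O`: 0.224 ug/mL
Compound 3, `CCCO/N=C/c1cc(OC)c2c(c1OC)C(=O)C=CC2=O`: 0.107 ug/mL

Compounds 1 and 3 share one core and differ only in the chain: hydrogen in place of butyl on a saturated chain carbon, three bonds along the chain from an oxygen on an unsaturated carbon. The step is a 2.0-fold lower number from compound 1 to compound 3 (0.30 log units; within the scatter), so the two read as the same within the usual scatter. Compound 2 carries a different core; the difference between the two cores is not broken down here. In this assay compound 2 gives the highest number of the three, but against compound 1 the gap lies within the scatter, so no order between compound 1 and compound 2 is claimed. Against compound 3 the gap lies beyond the scatter, and compound 3 gives the lower number of that pair.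

Compound 4, `CCCCCC/C(=N\OC)c1cc(OC)c2c(c1OC)C(=O)C=CC2=O`, is the shorter-chain partner of compound 2: hydrogen in place of butyl on a saturated chain carbon bound to an oxygen. It is the same kind of change as from compound 1 to compound 3, not the same change: there the carbon sat three bonds along the chain from an oxygen on an unsaturated carbon, here it is bound directly to an oxygen. With one pair only, nothing beyond that pair can be said about the trend.

The step expected from compound 2 to compound 4 is a 1.5-fold lower number from compound 2 to compound 4 (0.17 log units; within the scatter), and that rests on the step of the like change seen as a 2.0-fold lower number from compound 1 to compound 3 (0.30 log units; within the scatter). Compound 4 is therefore estimated at 0.15 ug/mL, with a range of 0.07 ug/mL to 0.4 ug/mL.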

Compound 4, concentration for half-maximal effect: 0.192 ug/mL
Compound 4: middle estimate off by 1.3-fold (0.11 log units), on the low side, within the range that was stated.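

In this assay, pentyloxy to methoxy on the core of compound 2 gives a 1.2-fold lower number from compound 2 to compound 4 (0.07 log units; within the scatter), so the two compounds read as the same within the usual scatter. Set beside the earlier step on the core of compound 1, the two steps do not differ: the same change on two cores in this assay, a 2.0-fold lower number (0.30 log units; within the scatter) from compound 1 to compound 3 and a 1.2-fold lower number (0.07 log units; within the scatter) from compound 2 to compound 4, 1.7-fold (0.23 log units) apart, within the scatter of two such steps

This shows that, on both cores, shortening the chain leaves the number within the scatter, and that the step on one core is compatible with the step on the other. It does not show that a real effect of chain length carries from one core to another, as neither step stands clear of the scatter, the two pairs start from different chain lengths, and two pairs set no rule for the series.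

The compounds shown leave open whether a chain longer than heptyl, or a chain ending in an amine or a carboxylic acid, would give a step that can be read beyond the scatter. For the compounds shown here, they also leave open what the difference between the two cores contributes, as no pair here changes the core alone.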